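This account rests on a few compounds, and the source may have more. Where it says the series, first, only, none or still open, it means among the compounds named here.

Compound 1, `COc1ncnc2c1ncn2[C@@H]1O[C@H](COC(=O)C(C)(C)C)[C@@H](OC(=O)C(C)(C)C)[C@@H]1OC(=O)C(C)(C)C`: 14000 nM
Compound 2, `CCCC(=O)O[C@H]1[C@H](OC(=O)CCC)[C@@H](CO)O[C@H]1n1cnc2c(OC)ncnc21`: 9600000 nM
Compound 3, `CCCCC(=O)O[C@H]1[C@H](OC(=O)CCCC)[C@@H](CO)O[C@H]1n1cnc2c(OC)ncnc21`: 694000 nM

All three were measured in a physicochemical assay for solubility, in phosphate buffer; on this read-out higher numbers stand for higher solubility and lower numbers for lower solubility. Compound 1 stands lowest of the three numbers; compound 3 is nearest to it and compound 2 furthest, and both gaps lie beyond the usual scatter of this assay.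

Compound 4, `COc1ncnc2c1ncn2[C@@H]1O[C@H](CO)[C@@H](OC(=O)C(C)(C)C)[C@@H]1OC(=O)C(C)(C)C`, has not yet been measured. It differs from compound 1 in one place: hydrogen in place of (tert-butyl)carbonyl on an oxygen on a saturated carbon. Cut one bond further out, the same change reads ((tert-butyl)carbonyl)oxy to hydroxy, or (((tert-butyl)carbonyl)oxy)methyl to hydroxymethyl. Among the measured compounds shown here, no measured pair shows this exact change, so its size can only be judged from the other compounds. Compound 2 carries a hydroxymethyl at that position and gives 9600000 nM; compound 3, likewise, gives 694000 nM. Both stand far above compound 1. The step from compound 1 to compound 4 is therefore expected to be a large rise, a 29-fold higher number from compound 1 to compound 4 (1.46 log units; beyond the scatter). The solubility of compound 4 is estimated at 400000 nM, within a range from 100000 nM to 1500000 nM, because compound 3 gives 694000 nM and is the closest comparison.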

Compound 4, solubility: 640000 nM
Estimate against measurement, compound 4: 1.6-fold (0.20 log units) below; measured number inside the range.
By their numbers in this assay, from the lowest: compound 1; then compounds 4 and 3 (each within the scatter of the next); then compound 2.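

In this assay, swapping the (tert-butyl)carbonyl on an oxygen on a saturated carbon for hydrogen, which turns (((tert-butyl)carbonyl)oxy)methyl into hydroxymethyl, gives a 46-fold higher number from compound 1 to compound 4 (1.66 log units; beyond the scatter). The two compounds differ in this one place only, and the other two (tert-butyl)carbonyl groups remain, so the step can be read as the size of this single change. The earlier compounds shown here could not show this, since the ones with a hydroxymethyl also differ from compound 1 in their other ester groups.

Nothing shown explains why the number rises by this much. As far as these compounds go, it remains open how a methyl ether, an acetyl or an amine-bearing ester would compare at this oxygen, and whether removing either of the other two (tert-butyl)carbonyl groups would give a similar step.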